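Sulfonyl aryl variation on a shared core, toward compound 4

The source may hold more compounds than are shown below. What is called first, only, known or untested is meant among the compounds shown, and "the series" means these compounds.

Measured so far:
compound 1 `Cc1ccccc1S(=O)(=O)Nc1ccc2oc(-c3ccccc3)nc2c1` gives > 63000 nM in an assay on isolated protein for inhibition of malate dehydrogenase, mitochondrial (Sus scrofa), with stated times of 45 min and 30 min (on this read-out higher numbers stand for weaker inhibition and lower numbers for stronger inhibition), a limit of the assay and not a number.
compound 2 `O=S(=O)(Nc1ccc2oc(-c3ccccc3)nc2c1)c1cccc(O)c1` gives > 63000 nM in this assay, likewise a limit.
compound 3 `O=S(=O)(Nc1ccc2oc(-c3ccccc3)nc2c1)c1cccs1` gives > 63000 nM in this assay, likewise a limit.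

Compound 3 thus stands where the other two stand, at the assay limit, as the limit of > 63000 nM in this assay, at which 3 of the 3 values shown sit, records. The steps a step that the two limits leave unreadable from compound 1 to compound 2, a step that the two limits leave unreadable from compound 1 to compound 3 and a step that the two limits leave unreadable from compound 2 to compound 3 are all unreadable in size, so no exchange of the aryl on the sulfonyl sulfur has yet shown a readable effect.

Compound 4 `CCc1ccc(S(=O)(=O)Nc2ccc3oc(-c4ccccc4)nc3c2)cc1` carries 4-ethylphenyl in place of thiophen-2-yl on a sulfonyl sulfur. With every measured step unreadable, no direction can be drawn from them. The expected step is a step that the limit leaves unreadable from compound 3 to compound 4, keeping compound 4 in the limit region. Compound 4 is estimated at 100000 nM (range 30000 nM to 400000 nM) in this assay, most probably reported again as a limit.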

Compound 4, half-maximal inhibitory concentration: > 63000 nM
Compound 4 gave a limit, no number (the forecaster's own chance of this, stated with the estimate: 85%); the middle value does not contradict the limit.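

Among the compounds shown here, no step from compound 1, compound 2 or compound 3 to compound 4 can be read, since all four compounds sit at one assay limit: the limit of > 63000 nM in this assay, at which 4 of the 4 values shown sit.
The compounds shown leave open whether any sulfonyl substituent on the shared core gives a measurable inhibition value.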